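Working notes on compounds 1 to 3

A few compounds are considered here, and "the series" means these few. Any claim that something is new, unique, unknown or untested is made for them only; others in the source may bear on it.

The series is followed in a functional assay on MDA-MB-231 cells (Homo sapiens) for cytotoxicity, read by MTT assay, with a stated time of 72 h, tested at 5 uM, in the absence of a further agent; on this read-out higher numbers stand for a weaker effect at the one concentration tested and lower numbers for a stronger effect. Compound 1 `CC1(C)CC(=O)Nc2ccc(Cl)cc21` gives 81.7% there, and compound 2 `CNC1=Nc2ccc(Cl)cc2C(C)(C)C1` gives 92.3%. Of the two numbers shown, compound 2 stands highest; the nearer figure belongs to compound 1, lower by a gap beyond the usual scatter, so compound 2 is the weaker of the pair at the one concentration tested. Within the data shown here, no step between measured compounds that differ in one place is available, so nothing recorded yet shows how a change of this kind shifts the read-out.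

Compound 3 `CCN(CC)CCCNC1=Nc2ccc(Cl)cc2C(C)(C)C1` is the next member. It differs from compound 2 as follows: 2-(diethylamino)ethyl in place of hydrogen on a saturated chain carbon bound to an amine nitrogen. Among the measured compounds shown here, with no comparable step measured, the expectation rests on the two values alone: a modest downward move in this assay is expected, of the size a number 17.3 percentage points lower from compound 2 to compound 3 (beyond the scatter), though a result within the scatter of compound 2 would not surprise. Compound 3 is accordingly estimated at 75%, with a range from 55% to 95%.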

Compound 3, a percentage reported as activity, at one concentration (the size of the read-out at that concentration, not a potency): 36.1%
Beside the measured number, compound 3's estimate is 38.9 percentage points above it, and the stated range ends above it.
By their numbers in this assay, from the lowest: compound 3; then compound 1; then compound 2.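

Among these compounds, the change from hydrogen to 2-(diethylamino)ethyl on a saturated chain carbon bound to an amine nitrogen gives the first recorded step: in this assay there is a number 56.2 percentage points lower from compound 2 to compound 3 (beyond the scatter) at the one concentration tested. This shows that the read-out is highly sensitive to what is carried at this place, since the lower number stands for a stronger effect. The measurements at hand offer nothing that bears on why the read-out moves so far.

With one step at this place, the part played by the terminal diethylamino group cannot be separated from that of the chain carrying it. On these data alone, a plain butyl chain without the amine, a morpholine at the chain end or a longer chain could each give a step of a different size, and how large those steps would be remains open.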